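Shortening the butyl chain on compound 3's aromatic nitrogen

The source may report more compounds than this note shows. Statements on the series, on what has been measured and on what is new or still open speak of the compounds shown alone.

Of the compounds shown here, three sharing one core have been measured in a functional assay with Alpha-1D adrenergic receptor (Homo sapiens) as the target, read by calcium flux; a higher number here means a larger maximal response, a lower number a smaller maximal response. Compound 1 `Cc1nc(-c2ccccc2NCC2=NCCN2)n(C)n1` gives 0% in this assay, and compound 2 `Cc1n[nH]c(-c2ccccc2NCC2=NCCN2)n1` gives 0%; the step of no change at the digits printed from compound 1 to compound 2 (within the scatter) shows that swapping a methyl for a hydrogen on an aromatic nitrogen left the maximal response unchanged. Compound 3 `CCCCn1ncnc1-c1ccccc1NCC1=NCCN1` stands apart: in this assay compound 3 gives 66%, the highest of the three numbers and beyond the scatter above both compound 1 and compound 2.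

Compound 4 `Cn1ncnc1-c1ccccc1NCC1=NCCN1` is compound 3 with a shorter chain on the aromatic nitrogen: hydrogen in place of propyl on a saturated chain carbon bound to an aromatic nitrogen. For the measured compounds named here, no measured step removes this propyl fragment, so the only bearing comes from the contrast between compound 3 with its butyl and compound 1 with its methyl on that nitrogen, where compound 1 also carries a further methyl. Compound 4 is therefore expected to lose most of the response, an estimated a number 46 percentage points lower from compound 3 to compound 4 (beyond the scatter) in this assay. For compound 4 a maximal response of 20% is estimated, within a range from 0% to 55%.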

Compound 4, largest response reached (reported as maximal response), in percent of the reference or control that the assay uses: 116%
Estimate against measurement, compound 4: 96 percentage points below; the measured number lies above the stated range.
By their numbers in this assay, from the lowest: compounds 1 and 2 (each within the scatter of the next); then compound 3; then compound 4.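

Cutting the chain on the aromatic nitrogen from butyl to methyl gives a number 50 percentage points higher from compound 3 to compound 4 (beyond the scatter) in this assay, so a long chain at this place is not required for a large maximal response. The methyl on that nitrogen does not by itself account for the silence of compound 1: hydrogen in place of methyl on an aromatic carbon gives a number 116 percentage points higher from compound 1 to compound 4 (beyond the scatter), and 1-methyl-1H-1,2,4-triazol-5-yl in place of 3-methyl-1H-1,2,4-triazol-5-yl gives a number 116 percentage points higher from compound 2 to compound 4 (beyond the scatter). Nothing available explains why either change has this effect.

Open, as far as these compounds go, is how the response runs between methyl and butyl, with an ethyl or propyl chain on that nitrogen. Also open, from the compounds shown here alone, is what a plain hydrogen on that nitrogen, or an ethyl group or chlorine on the aromatic carbon, would give.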